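Swapping Dichloro for Dimethoxy on the Benzyl Arm

A few compounds are considered here, and "the series" means these few. Any claim that something is new, unique, unknown or untested is made for them only; others in the source may bear on it.

Measured so far in a functional assay on MIA PaCa-2 cells (Homo sapiens) for inhibition, read by MTT assay, with a stated time of 72 h; on this read-out higher numbers stand for weaker inhibition of growth and lower numbers for stronger inhibition of growth:
compound 1 `O=S(=O)(NCCCNCc1ccccc1Cl)c1cc(C(F)(F)F)cc(C(F)(F)F)c1` gives 11000 nM
compound 2 `CC(C)(C)c1ccc(CNCCCNS(=O)(=O)c2cc(C(F)(F)F)cc(C(F)(F)F)c2)cc1` gives 2300 nM
compound 3 `O=S(=O)(NCCCNCc1ccc(Cl)c(Cl)c1)c1cc(C(F)(F)F)cc(C(F)(F)F)c1` gives 2700 nM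

The three compounds share one core and differ only in the aryl group sitting on a saturated chain carbon bound to an amine nitrogen. On the numbers shown, compound 3 stands second highest of the three. Its nearest neighbour is compound 2, separated by a 1.2-fold higher number from compound 2 to compound 3 (0.07 log units; within the scatter), which lies within the scatter; the furthest is compound 1, with a 4.1-fold lower number from compound 1 to compound 3 (0.61 log units; beyond the scatter), clearly beyond it.

Compound 4 `COc1ccc(CNCCCNS(=O)(=O)c2cc(C(F)(F)F)cc(C(F)(F)F)c2)cc1OC` has not yet been measured in this assay. It arises from compound 3 by 3,4-dimethoxyphenyl in place of 3,4-dichlorophenyl on a saturated chain carbon bound to an amine nitrogen. Among the measured compounds shown here, no measured step replaces a chlorine-bearing ring with a methoxy-bearing one, so there is no direct precedent. The steps that exist, a 4.8-fold lower number from compound 1 to compound 2 (0.68 log units; beyond the scatter) and a 4.1-fold lower number from compound 1 to compound 3 (0.61 log units; beyond the scatter), show that changing this ring can shift the number modestly, while compound 2 and compound 3 show that two quite different patterns can sit within the scatter of each other. The expected step is therefore small, toward a slightly higher number, a 2.0-fold higher number from compound 3 to compound 4 (0.31 log units; beyond the scatter). Compound 4 is estimated at 5500 nM, with a range from 2200 nM to 14000 nM.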

Compound 4, concentration for 50% growth inhibition: 2800 nM
The estimate for compound 4 lay 2.0-fold (0.29 log units) above the measured number; the range from low to high includes it.
By their numbers in this assay, from the lowest: compounds 2, 3 and 4 (each within the scatter of the next); then compound 1.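

In this assay this position accepts 3,4-dimethoxyphenyl as readily as 3,4-dichlorophenyl, with a 1.0-fold higher number from compound 3 to compound 4 (0.02 log units; within the scatter) and a 1.2-fold higher number from compound 2 to compound 4 (0.09 log units; within the scatter) both inside the usual scatter. Compounds 2, 3 and 4 carry quite different rings yet read alike, and the two hydrogen-bond acceptors that enter with 3,4-dimethoxyphenyl bring no change beyond that scatter. Compound 1 alone stands apart, and a 3.9-fold lower number from compound 1 to compound 4 (0.59 log units; beyond the scatter) adds a third step beyond the scatter away from its 2-chlorophenyl ring.

Going by these compounds, what a single methoxy group or a carboxylic acid on this ring, or a longer chain in the shared core, would do to the number remains open. Nothing at hand explains why these three rings read alike or why compound 1 differs from them.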